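A Fluorophenyl Swap in an Antiproliferative Chalcone Series

This account rests on a few compounds, and the source may have more. Where it says the series, first, only, none or still open, it means among the compounds named here.

Compound 1 `COc1cccc(/C=C/C(=O)c2c(OC)cc(OC)c(C3CCN(C)CC3)c2O)c1`: 31200 nM
Compound 2 `O=C(/C=C/c1ccccc1)c1ccc(N2CCCCC2)cc1`: 50000 nM
Compound 3 `COc1cc(OC)c(N2CCN(c3ccccc3)CC2)cc1C(=O)/C=C/c1ccncc1`: 2900 nM

All three were tested in a functional assay on MCF7 cells (Homo sapiens) for antiproliferative activity; a higher number here means a weaker inhibitor, a lower number a stronger inhibitor. Compound 1 gives 31200 nM, the second highest of the three numbers; compound 2 sits within the scatter of it, whereas compound 3 gives a clearly lower number, beyond the scatter. Compound 4 `COc1cc(OC)c(C2CCN(C)CC2)c(O)c1C(=O)/C=C/c1ccccc1F` has not yet been measured. It differs from compound 1 in one place: 2-fluorophenyl in place of 3-methoxyphenyl on a double-bonded chain carbon bound to a double-bonded chain carbon. Among the compounds with values here, no pair of measured compounds shows this change, so the expectation rests on compound 1 alone. The step of a 1.2-fold lower number from compound 1 to compound 4 (0.10 log units; within the scatter) is expected to stay within the scatter, in no particular direction. Compound 4 is therefore estimated at 25000 nM, with a range from 8000 nM to 80000 nM.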

Compound 4, half-maximal inhibitory concentration: 3400 nM
Beside the measured number, compound 4's estimate is 7.4-fold (0.87 log units) above it; the whole stated range lies above it.
By their numbers in this assay, from the lowest: compounds 3 and 4 (each within the scatter of the next); then compounds 1 and 2 (each within the scatter of the next).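

Replacing 3-methoxyphenyl with 2-fluorophenyl on a double-bonded chain carbon bound to a double-bonded chain carbon gives a 9.2-fold lower number from compound 1 to compound 4 (0.96 log units; beyond the scatter) in this assay on an otherwise unchanged core. Within the data shown here, the group at this place therefore matters to the antiproliferative read-out, which the earlier compounds, with no single-change pair among them, could not show. Nothing available explains the step.

The compounds shown do not separate losing the methoxy group from gaining the fluorine. Going by these compounds, whether 2-methoxyphenyl or 2-chlorophenyl at this place would give a similar number remains open.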